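This account rests on a few compounds, and the source may have more. Where it says the series, first, only, none or still open, it means among the compounds named here.

Three compounds share one core and differ only in the groups on their two outer rings. Compound 1 `FC(F)(F)c1ccc(Nc2ncnc3sc(Nc4c(Cl)cccc4Cl)nc23)cc1` gives 12 nM in a functional assay on HEK293 cells for antagonist activity at transient receptor potential cation channel subfamily V member 1 (Homo sapiens), read by calcium flux; on this read-out lower numbers stand for stronger inhibition and higher numbers for weaker inhibition. Compound 2 `FC(F)(F)c1ccc(Nc2ncnc3sc(Nc4ccccc4Cl)nc23)cc1`, which lacks one of the two chloro groups, gives 64 nM in this assay, and the step is a 5.3-fold higher number from compound 1 to compound 2 (0.73 log units; beyond the scatter). Compound 3 `CSc1ccc(Nc2ncnc3sc(Nc4c(Cl)cccc4Cl)nc23)cc1` gives 96 nM in this assay, the highest of the three numbers; it sits within the scatter of compound 2, while the step from compound 1 is an 8.0-fold higher number from compound 1 to compound 3 (0.90 log units; beyond the scatter).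

Compound 4 `NS(=O)(=O)c1ccc(Nc2ncnc3sc(Nc4c(Cl)cccc4Cl)nc23)cc1` is not yet measured. It differs from compound 3 in one place: sulfamoyl in place of methylsulfanyl on an aromatic carbon. For the measured compounds named here, of the measured steps, only the one from compound 1 to compound 3 changes the group on this same ring, and it shows that swapping this group can shift the number modestly, as in an 8.0-fold higher number from compound 1 to compound 3 (0.90 log units; beyond the scatter). The step from compound 1 to compound 2 concerns the other ring and says little here. Going by the values given here, no compound carries a sulfamoyl group, so the direction is open; a shift of similar size either way seems plausible. Compound 4 is therefore expected to give about 50 nM in this assay, with a range from 12 nM to 250 nM, which would mean an expected step of a 1.9-fold lower number from compound 3 to compound 4 (0.28 log units; within the scatter).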

Compound 4, half-maximal inhibitory concentration: > 5000 nM
Compound 4: only a limit was reported; the forecaster's own chance of this, stated with the estimate: 5%; middle value at least 100-fold (2.00 log units) from the limit.
By their numbers in this assay, from the lowest: compound 1; then compounds 2 and 3 (each within the scatter of the next). At a limit, above all of these: compound 4.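

For the compounds shown here, this result shows that the group on this ring, para to a large group, matters far more than the earlier compounds suggested. The earlier swap on this ring was modest, with an 8.0-fold higher number from compound 1 to compound 3 (0.90 log units; beyond the scatter) in this assay, whereas sulfamoyl in place of methylsulfanyl gives an at least 52-fold higher number from compound 3 to compound 4 (1.71 log units; beyond the scatter), and sulfamoyl in place of trifluoromethyl gives an at least 410-fold higher number from compound 1 to compound 4 (2.61 log units; beyond the scatter), so this one change on an otherwise unchanged scaffold is enough to produce a large step. Compound 4 is reported only as a limit, so these two steps give a minimum size and not an exact one: the limit of > 5000 nM in this assay, at which 1 of the 4 values shown sits.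

The compounds shown do not reveal which difference between sulfamoyl and the other two groups goes with this large step, whether its greater number of heavy atoms, its nitrogen or its hydrogen-bond donor. Going by these compounds alone, a methylsulfonyl group, which has carbon where sulfamoyl has nitrogen, or an amine or a carboxylic acid on the same aromatic carbon, would help to separate these possibilities, and a sulfamoyl compound with only one chloro group would test whether the two changes act independently.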